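Swapping the Aryl Group for a Styryl Arm

The source may report more compounds than this note shows. Statements on the series, on what has been measured and on what is new or still open speak of the compounds shown alone.

Three close relatives of one core have been examined in a functional assay on Ehrlich cells (Mus musculus) for cytotoxicity, tested at 50 ug/mL; a higher number here means a stronger effect of the compound at the concentration tested, a lower number a weaker effect. Compound 1, `COc1cc(N2C(N)=C(C#N)C(c3cccc([N+](=O)[O-])c3)C3=C2CC(C)(C)CC3=O)cc(OC)c1OC`, gives 30%. Compound 2, `COc1cc(N2C(N)=C(C#N)C(c3ccc([N+](=O)[O-])cc3)C3=C2CC(C)(C)CC3=O)cc(OC)c1OC`, gives 70%, and compound 3, `COc1cc(N2C(N)=C(C#N)C(c3ccccc3Cl)C3=C2CC(C)(C)CC3=O)cc(OC)c1OC`, gives 20%. Compound 1 thus stands second highest of the three; its reading and that of compound 3 lie within the scatter of each other, while compound 2 sits well apart.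

Compound 4, `COc1cc(N2C(N)=C(C#N)C(/C=C/c3ccccc3)C3=C2CC(C)(C)CC3=O)cc(OC)c1OC`, differs from compound 1 in one place: 2-phenylethenyl in place of 3-nitrophenyl on a saturated ring carbon. Two measured steps start from compound 1 and change the same group. Moving the nitro group gave a number 40 percentage points higher from compound 1 to compound 2 (beyond the scatter), whereas a different ring, 2-chlorophenyl, gave a number 10 percentage points lower from compound 1 to compound 3 (within the scatter). The same position therefore admits both a large rise and no real change. A 2-phenylethenyl group resembles neither test, so the outcome is uncertain, and the expected step of a number 5 percentage points higher from compound 1 to compound 4 (within the scatter) is small. Compound 4 is therefore estimated at 35%, with a range from 15% to 60%.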

Compound 4, a percentage reported as activity, at one concentration (the size of the read-out at that concentration, not a potency): 30%
The estimate for compound 4 lay 5 percentage points above the measured number; the range from low to high includes it.
By their numbers in this assay, from the lowest: compounds 3, 1 and 4 (each within the scatter of the next); then compound 2.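

The position does not depend on a nitro group to give this level of effect: 2-phenylethenyl, with no hydrogen-bond acceptors, gives no change at the digits printed from compound 1 to compound 4 (within the scatter) when it replaces 3-nitrophenyl. It also gives a number 10 percentage points higher from compound 3 to compound 4 (within the scatter) when it replaces 2-chlorophenyl, so three different groups now share one level. Only 4-nitrophenyl stands apart, with a number 40 percentage points lower from compound 2 to compound 4 (beyond the scatter) on the change to 2-phenylethenyl, and nothing available here explains that difference.

From the compounds shown here alone, whether the high reading of compound 2 needs the nitro group itself remains open, since 4-chlorophenyl or 4-methoxyphenyl could show if another group in that place gives the same rise. Also open, going by these compounds, is what a plain butyl chain, with no aromatic ring at all, would do at this position.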